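Amine alkyl size on the flavone side chain

The compounds below may be only part of what the source reports. "The series", "measured", "known", "first", "only" and "open" are said of these compounds alone.

Measured compounds: compound 1 `CN(C)CCCOc1c(OCc2ccccc2)cc(O)c2c(=O)cc(-c3ccccc3)oc12`, compound 2 `CN(C)CCCCOc1c(OCc2ccccc2)cc(O)c2c(=O)cc(-c3ccccc3)oc12`.

In a functional assay on A549 cells (Homo sapiens) for cytotoxicity, read by MTT assay, with a stated time of 72 h (a higher number here means a weaker inhibitor, a lower number a stronger inhibitor), compound 1 gives 2910 nM; compound 2 gives 1090 nM, the lower of the two numbers. Within the data shown here, the only measured step, a 2.7-fold lower number from compound 1 to compound 2 (0.43 log units; beyond the scatter), alters the chain length, not the groups on nitrogen. Compound 3 `CCN(CC)CCCCOc1c(OCc2ccccc2)cc(O)c2c(=O)cc(-c3ccccc3)oc12` carries diethylamino in place of dimethylamino on a saturated chain carbon, four bonds along the chain from an oxygen on an aromatic ring. Among the measured compounds shown here, no measured step changes the amine alkyls, so the step in this assay is expected to be small, at most a modest decrease: a 1.3-fold lower number from compound 2 to compound 3 (0.11 log units; within the scatter). Compound 3 is estimated at 850 nM, within 350 nM to 2200 nM.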

Compound 3, half-maximal inhibitory concentration: 3910 nM
Beside the measured number, compound 3's estimate is 4.6-fold (0.66 log units) below it, outside the stated range (above it).
By their numbers in this assay, from the lowest: compound 2; then compounds 1 and 3 (each within the scatter of the next).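

In this assay, among these compounds, the groups on nitrogen are not neutral at this position: diethylamino in place of dimethylamino on the four-carbon-linked compounds gives a 3.6-fold higher number from compound 2 to compound 3 (0.55 log units; beyond the scatter), the first measured change in the amine alkyls. The advantage of compound 2 does not persist with diethylamino, and the other listed comparison reads a 1.3-fold higher number from compound 1 to compound 3 (0.13 log units; within the scatter). Nothing available here accounts for this loss.

Still open, going by these compounds, is how a pyrrolidine or morpholine amine would read on this chain. Also open, on these data alone, is whether a longer chain would lower the number with dimethylamino or diethylamino.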